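A few compounds are considered here, and "the series" means these few. Any claim that something is new, unique, unknown or untested is made for them only; others in the source may bear on it.

Compound 1 `COc1cc(/C=C2\Cc3ccccc3/C(=C\c3ccc([N+](=O)[O-])cc3)C2=O)ccc1O` in a functional assay on HPC cells (Homo sapiens) for cytotoxicity (a higher number here means that more compound is tolerated, a lower number that less compound is tolerated), gives 83000 nM. Compound 2 `COc1ccc(/C=C2\Cc3ccccc3/C(=C\c3ccc([N+](=O)[O-])cc3)C2=O)cc1` is known in this assay only as a limit, > 400000 nM (the limit of > 400000 nM in this assay, at which 1 of the 2 values shown sits). For the measured compounds named here, the one measured step, an at least 4.8-fold higher number from compound 1 to compound 2 (0.68 log units; beyond the scatter), went with removal of the hydroxy of 4-hydroxy-3-methoxyphenyl. Compound 3 `O=C1/C(=C/c2ccc(O)cc2)Cc2ccccc2/C1=C\c1ccc([N+](=O)[O-])cc1` carries the change (hydrogen in place of methyl on an oxygen on an aromatic ring), so a free phenol returns, though without the methoxy of compound 1. Because compound 1, the only phenol measured, sits at 83000 nM, a less tolerated compound is expected. The expected step is an at least 2.6-fold lower number from compound 2 to compound 3 (0.42 log units; beyond the scatter). Compound 3 is therefore estimated at 150000 nM, in the range 50000 nM to 450000 nM.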

Compound 3, half-maximal cytotoxic concentration: 113000 nM
Beside the measured number, compound 3's estimate is 1.3-fold (0.12 log units) above it; the measured number falls inside the stated range.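

In this assay, methoxy to hydroxy at this position gives an at least 3.5-fold lower number from compound 2 to compound 3 (0.54 log units; beyond the scatter), so the lower tolerated concentration seen with a free hydroxy does not depend on the neighbouring methoxy of 4-hydroxy-3-methoxyphenyl. Loss of that methoxy gives a 1.4-fold higher number from compound 1 to compound 3 (0.13 log units; within the scatter), so the two phenols are not told apart. Compound 2 stands only as a limit: the limit of > 400000 nM in this assay, at which 1 of the 3 values shown sits.

Still open, on these data alone, is how an amine or a carboxylic acid in place of the hydroxy would stand in this assay. As far as these compounds go, whether a longer chain on that oxygen behaves like methoxy also remains open.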